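From methoxy to benzyloxy: a step still unmeasured

The source may report more compounds than this note shows. Statements on the series, on what has been measured and on what is new or still open speak of the compounds shown alone.

Going by the values given here, in a functional assay on thoracic aorta (Rattus norvegicus, strain Wistar), with a stated time of 15 min (a higher number here means that more compound is needed for the effect, a lower number that less compound is needed), compound 2 `COc1ccc(Br)cc1C(C)NC(=O)N(C)S(=O)(=O)c1ccccc1` gives 16800 nM as the lower of the two numbers so far. Compound 1 `CC(NC(=O)NS(=O)(=O)c1ccccc1)c1cc(Br)ccc1OCc1ccccc1` gives 130000 nM as the higher number, a gap beyond the scatter. Compound 3 `CC(NC(=O)N(C)S(=O)(=O)c1ccccc1)c1cc(Br)ccc1OCc1ccccc1` follows from compound 2 through phenyl in place of hydrogen on a saturated chain carbon bound to an oxygen on an aromatic ring with phenyl in place of hydrogen on a saturated chain carbon bound to an oxygen on an aromatic ring, which reads as methoxy to benzyloxy. Among the compounds with values here, compound 1 also bears benzyloxy and stands at 130000 nM as the only guide. A rise in the number beyond the scatter is therefore expected in this assay with a 2.4-fold higher number from compound 2 to compound 3 (0.38 log units; beyond the scatter) as the estimated step. For compound 3 the estimate is 40000 nM with an expected range from 12000 nM to 130000 nM overall.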

Compound 3, half-maximal effective concentration: 60300 nM
The estimate for compound 3 lay 1.5-fold (0.18 log units) below the measured number; low and high end bracket the measured number.
By their numbers in this assay, from the lowest: compound 2; then compound 3; then compound 1.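

In this assay the change from methoxy to benzyloxy is now seen alone, as a 3.6-fold higher number from compound 2 to compound 3 (0.56 log units; beyond the scatter), so benzyloxy at this place raises the number with the amide-type nitrogen methylated. With benzyloxy kept, methyl in place of hydrogen on that nitrogen gives a 2.2-fold lower number from compound 1 to compound 3 (0.33 log units; beyond the scatter), a modest step in the opposite direction. No available evidence gives a reason for either step.

Open, on these data alone, is whether the rise needs the phenyl ring itself or follows from chain length alone, a question that ethoxy or a longer unbranched alkoxy chain at this place would address.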